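Fluoro in place of hydrogen: working notes on four compounds

A few compounds are considered here, and "the series" means these few. Any claim that something is new, unique, unknown or untested is made for them only; others in the source may bear on it.

Measured in a functional assay on PBMC cells (Homo sapiens) for inhibition, read by HTRF, with stated times of 15 min and 24 h; on this read-out higher numbers stand for weaker inhibition and lower numbers for stronger inhibition:
compound 1 `O=C(Nc1ccc2c(c1)B(O)OC2)c1ccccc1C(F)(F)F`, 4400 nM
compound 2 `O=C(Nc1ccc2c(c1)B(O)OC2)c1cccc(C(F)(F)F)c1`, a limit only: > 10000 nM
compound 3 `O=C(Nc1ccc2c(c1)B(O)OC2)c1c(F)cccc1C(F)(F)F`, 370 nM

Compound 3 differs from compound 1 by fluoro in place of hydrogen on an aromatic carbon, and that step is a 12-fold lower number from compound 1 to compound 3 (1.08 log units; beyond the scatter). Compound 1 and compound 2 have the same atoms joined differently; the difference between the two cores is not broken down here. Compound 4 `O=C(Nc1ccc2c(c1)B(O)OC2)c1cc(C(F)(F)F)ccc1F` is not yet measured; it differs from compound 2 by fluoro in place of hydrogen on an aromatic carbon. The surroundings differ: in compound 3 the entering fluoro is meta to a trifluoromethyl group, in compound 4 para to it, so this is the same kind of change, not the same change. Compound 2 is known only as a limit, (the limit of > 10000 nM in this assay, at which 1 of the 3 values shown sits), so the starting point is open. The step from compound 2 to compound 4 in this assay is expected to be an at least 3.3-fold lower number from compound 2 to compound 4 (0.52 log units; beyond the scatter), resting on the earlier 12-fold lower number from compound 1 to compound 3 (1.08 log units; beyond the scatter) and weakened by that limit. Compound 4 is estimated at 3000 nM, between 700 nM and 12000 nM.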

Compound 4, half-maximal inhibitory concentration: > 100000 nM
Compound 4: a limit, no number (the forecaster's own chance of this, stated with the estimate: 35%); at least 33-fold (1.52 log units) between middle value and limit.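

In this assay, compound 2 and compound 4 are each known only as a limit, so the step between them cannot be read. The compounds shown leave open what size of change, if any, fluoro para to a trifluoromethyl group brings to compound 2.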